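Aorta inhibition series: phenyl swap on the ethoxycarbonyl core

A few compounds are considered here, and "the series" means these few. Any claim that something is new, unique, unknown or untested is made for them only; others in the source may bear on it.

Measured in a functional assay on aorta (Rattus norvegicus, strain Wistar) for inhibition; a lower number here means that less compound is needed, a higher number that more compound is needed for the effect:
compound 1 `O=C(CO[N+](=O)[O-])NNC(=O)c1ccc(-n2[nH]c(=O)cc2-c2ccccc2O)cc1`: 17.8 ug/mL
compound 2 `O=C(CO[N+](=O)[O-])NNC(=O)c1ccc(-n2[nH]c(=O)cc2-c2ccc(Cl)cc2)cc1`: 21.3 ug/mL
compound 3 `CCOC(=O)c1c(-c2ccccc2O)n(-c2ccc(C(=O)NNC(=O)CO[N+](=O)[O-])cc2)[nH]c1=O`: 70.8 ug/mL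

Compound 1 and compound 2 differ by 4-chlorophenyl in place of 2-hydroxyphenyl on an aromatic carbon, and the step is a 1.2-fold higher number from compound 1 to compound 2 (0.08 log units; within the scatter). Compound 3 carries a different core: against compound 1 it shows (ethoxycarbonyl in place of hydrogen on an aromatic carbon), with a step of a 4.0-fold higher number from compound 1 to compound 3 (0.60 log units; beyond the scatter). Compound 4 `CCOC(=O)c1c(-c2ccc(Cl)cc2)n(-c2ccc(C(=O)NNC(=O)CO[N+](=O)[O-])cc2)[nH]c1=O` has not yet been measured in this assay. Against compound 3 it shows (4-chlorophenyl in place of 2-hydroxyphenyl on an aromatic carbon); the surroundings differ in that the changed aromatic carbon here is also next to the ring atom that bears an ethoxycarbonyl group (5 heavy atoms), so this is the same kind of change as that from compound 1 to compound 2, not the same. For compound 4 the step is expected to be a 1.2-fold higher number from compound 3 to compound 4 (0.08 log units; within the scatter), resting on the earlier step of a 1.2-fold higher number from compound 1 to compound 2 (0.08 log units; within the scatter) lying within the scatter. Compound 4 is therefore estimated at 85 ug/mL, between 45 ug/mL and 160 ug/mL.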

Compound 4, half-maximal effective concentration: 50.2 ug/mL
Estimate against measurement, compound 4: 1.7-fold (0.23 log units) above, within the range that was stated.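

In this assay, 4-chlorophenyl in place of 2-hydroxyphenyl on the ethoxycarbonyl core gives a step within the scatter (a 1.4-fold lower number from compound 3 to compound 4 (0.15 log units; within the scatter)), and this step does not differ from the one on the core of compound 1: the same change on two cores in this assay, a 1.2-fold higher number (0.08 log units; within the scatter) from compound 1 to compound 2 and a 1.4-fold lower number (0.15 log units; within the scatter) from compound 3 to compound 4, 1.7-fold (0.23 log units) apart, within the scatter of two such steps.
Ethoxycarbonyl in place of hydrogen gives a step beyond the scatter with 4-chlorophenyl present (a 2.4-fold higher number from compound 2 to compound 4 (0.37 log units; beyond the scatter)), and this step does not differ from the one with 2-hydroxyphenyl present: the same change on two cores in this assay, a 4.0-fold higher number (0.60 log units; beyond the scatter) from compound 1 to compound 3 and a 2.4-fold higher number (0.37 log units; beyond the scatter) from compound 2 to compound 4, 1.7-fold (0.23 log units) apart, within the scatter of two such steps.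
Both changes therefore carry across these four compounds, but two pairs per change do not show that they would carry to other groups, and they give no cause for either step.

Open, as far as these compounds go, is whether the ethoxycarbonyl step persists with a carboxylic acid or a primary amide at that ring carbon. Also open, from the compounds shown here alone, is whether the aryl swap stays this small with an aminophenyl or an unsubstituted phenyl group.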